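Triazole series: trimming the chain on compound 3

A few compounds are considered here, and "the series" means these few. Any claim that something is new, unique, unknown or untested is made for them only; others in the source may bear on it.

Of the compounds shown here, three of a shared core have been read in a functional assay on cells for positive allosteric modulation of metabotropic glutamate receptor 2 (Homo sapiens), read by fluorescence and calcium flux, with a stated time of 30 min; on this read-out lower numbers stand for an effect already at smaller amounts and higher numbers for an effect only at larger amounts of compound. Compound 1 `c1ccc(-c2ccc(Cn3nnc4ccccc43)cc2)cc1` carries a biaryl methylene on the ring nitrogen and gives 155 nM in this assay. Compound 2 `Fc1cc(Cl)ccc1-c1ccc(Cn2nnc3c(Br)cccc32)cn1`, with a halogenated biaryl methylene and a bromine on the core, gives 6 nM in this assay. Compound 3 `CC(C)Cn1nnc2c(Br)cccc21`, which keeps the bromine but carries only an isobutyl on the ring nitrogen, gives 140 nM in this assay. Among the three numbers compound 3 holds the second highest; its number and that of compound 1 lie within the scatter of each other, so no order between them is claimed, while compound 2 sits well apart, beyond the scatter.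

Compound 4 `Cn1nnc2c(Br)cccc21` is not yet measured. The change from compound 3 is hydrogen in place of isopropyl on a saturated chain carbon bound to an aromatic nitrogen. Going by the values given here, no measured pair in this set shows that move, so the direction rests on the pattern that the larger nitrogen substituents of compound 1 and compound 2 gave the lower numbers. Compound 4 is therefore expected to move toward a higher number, by a step of an 11-fold higher number from compound 3 to compound 4 (1.03 log units; beyond the scatter), with an estimated value of 1500 nM in this assay and a range from 400 nM to 8000 nM.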

Compound 4, half-maximal effective concentration: > 5000 nM
Compound 4: no number, only a limit; the forecaster's own chance of this, stated with the estimate: 20%; middle value at least 3.3-fold (0.52 log units) from the limit.
By their numbers in this assay, from the lowest: compound 2; then compounds 3 and 1 (each within the scatter of the next). At a limit, above all of these: compound 4.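

Hydrogen in place of isopropyl on a saturated chain carbon bound to an aromatic nitrogen gives the first pair in the set that differs in one place, and it reads as a large step in this assay: an at least 35-fold higher number from compound 3 to compound 4 (1.55 log units; beyond the scatter). In this assay compound 4 gives > 5000 nM, which is a limit of the assay and not a number. The step carries that limit with it, so it is read as a floor on the change at this position and not as its size: the limit of > 5000 nM in this assay, at which 1 of the 4 values shown sits.

Still open, from the compounds shown here alone, is how the number runs along the series from methyl to isobutyl and beyond, for instance with an ethyl or a longer chain, or with a chain ending in an amine or a carboxylic acid. Also open, going by these compounds, is how the isobutyl compares with a biaryl methylene on an otherwise identical core, as compound 1 and compound 2 each differ from compound 3 in more than one place, and any link between chain size and the numbers across those compounds cannot be read.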